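A second chloro on a dichlorinated purine-like core

The compounds below may be only part of what the source reports. "The series", "measured", "known", "first", "only" and "open" are said of these compounds alone.

Compound 1 `ClCc1cccc(Cn2cnc3ncnc(Cl)c32)c1` carries a chloromethyl benzyl arm on a fused two-ring core with one chloro group. In a functional assay on BT-549 cells (Homo sapiens) for cytotoxicity, read by sulforhodamine B assay, with a stated time of 48 h (a lower number here means a stronger inhibitor of growth, a higher number a weaker inhibitor of growth), compound 1 gives 28800 nM. Its closest neighbour is compound 2 `ClCc1cccc(Cn2cnc3c(Cl)ncnc32)c1`, where the chloro sits at a different position of the core; in this assay compound 2 gives 30200 nM. The two numbers lie within the usual scatter of each other, so neither compound can be called the stronger or the weaker inhibitor of growth on these data.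

Compound 3 `ClCc1cccc(Cn2cnc3nc(Cl)nc(Cl)c32)c1` is built from compound 1 by a single change: chloro in place of hydrogen on an aromatic carbon. Among the compounds with values here, no measured pair in this set shows what such an addition does, so the size of the step cannot be read from earlier results. Within the data shown here, with only two measured compounds, both sitting close together, the expectation is a small step at most, and the direction is open; an expected step of a 1.3-fold lower number from compound 1 to compound 3 (0.12 log units; within the scatter) from compound 1 to compound 3 is estimated. Compound 3 is therefore expected to give about 22000 nM, most likely between 8000 nM and 60000 nM.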

Compound 3, concentration for total growth inhibition: 1730 nM
Estimate against measurement, compound 3: 13-fold (1.10 log units) above, outside the stated range (below it).
By their numbers in this assay, from the lowest: compound 3; then compounds 1 and 2 (each within the scatter of the next).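

In this assay, chloro in place of hydrogen on an aromatic carbon, between two ring nitrogen atoms, gives a 17-fold lower number from compound 1 to compound 3 (1.22 log units; beyond the scatter) and so a clearly stronger inhibitor of growth. Within the data shown here, compounds 1 and 2 lie within the scatter of each other and gave no sign of such a step, so this position is the first place in the set where a change makes a clear difference. The change adds only one heavy atom, which shows that a very small edit at this position can carry a large step in this assay. No measurement shown here offers an explanation for the size of this step.

Whether the step belongs to chloro itself stays open, since other small groups at this position, such as a fluoro, a methoxy group or an amine, are not among the compounds shown. Also open, going by these compounds, is whether the same step would appear without the chloro group that compound 3 carries from compound 1, or with a different arm in place of the chloromethyl benzyl arm.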